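The compounds below may be only part of what the source reports. "The series", "measured", "known", "first", "only" and "open" are said of these compounds alone.

In a functional assay on HepG2 cells (Homo sapiens) for antiproliferative activity, read by MTT assay, with a stated time of 24 h (on this read-out lower numbers stand for stronger inhibition and higher numbers for weaker inhibition), compound 1 `O=[N+]([O-])c1cccc(CSc2nnc(-c3ccc4c(c3)OCCO4)n2-c2ccccc2)c1` gives 49300 nM and compound 2 `Fc1cccc(F)c1CSc1nnc(-c2ccc3c(c2)OCCO3)n1-c1ccccc1` gives 2070 nM, the lower of the two numbers. Going on to compound 3 `Brc1ccc(CSc2nnc(-c3ccc4c(c3)OCCO4)n2-c2ccccc2)cc1` puts 4-bromophenyl in place of 2,6-difluorophenyl on a saturated chain carbon bound to a sulfur, (4-bromophenyl in place of 2,6-difluorophenyl on a saturated chain carbon bound to a sulfur). Among the measured compounds shown here, the one measured step at this place, a 24-fold lower number from compound 1 to compound 2 (1.38 log units; beyond the scatter), is large, so the number can move far here, although no 4-bromophenyl compound has been measured. A moderate rise is therefore expected for compound 3, a 3.9-fold higher number from compound 2 to compound 3 (0.59 log units; beyond the scatter). The estimated value for compound 3 is 8000 nM, with an expected range of 1800 nM to 35000 nM.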

Compound 3, half-maximal inhibitory concentration: 7940 nM
For compound 3 the middle estimate is 1.0-fold (0.00 log units) above the measured one, and the stated range covers the measured number.
By their numbers in this assay, from the lowest: compound 2; then compound 3; then compound 1.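

At this position on a saturated chain carbon bound to a sulfur, this assay now separates three aryl groups, with 4-bromophenyl taking the middle place: there is a 3.8-fold higher number from compound 2 to compound 3 (0.58 log units; beyond the scatter) and also a 6.2-fold lower number from compound 1 to compound 3 (0.79 log units; beyond the scatter) on the other side. Both steps lie beyond the scatter, so the aryl group sets the number in graded fashion and not just in one large jump. No measured evidence accounts for this order.

The compounds shown leave open how a plain phenyl, a 4-chlorophenyl or a carboxylic acid on this ring would read. Because 4-bromophenyl and 2,6-difluorophenyl differ in both halogen and ring pattern, they also leave open which of these matters.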